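Solubility notes: aryl substituent swaps on the shared core

A few compounds are considered here, and "the series" means these few. Any claim that something is new, unique, unknown or untested is made for them only; others in the source may bear on it.

Measured so far:
compound 1 `CCc1ccc(-c2nc3c(c(C)nn3-c3ccccc3)c(-c3ccccc3[N+](=O)[O-])c2C#N)cc1`: 1200 nM
compound 2 `CCc1ccc(-c2nc3c(c(C)nn3-c3ccccc3)c(-c3ccccc3I)c2C#N)cc1`: 8500 nM

In a physicochemical assay for solubility, read by spectrophotometry, in phosphate buffer, with a stated time of 18 h, at pH 7.4 (on this read-out lower numbers stand for lower solubility and higher numbers for higher solubility), compound 2 stands highest of the two numbers, with compound 1 the nearest at a 7.1-fold higher number from compound 1 to compound 2 (0.85 log units; beyond the scatter). Compound 3 `CCc1ccc(-c2nc3c(c(C)nn3-c3ccccc3)c(-c3ccccc3OC(F)(F)F)c2C#N)cc1` is not yet measured. It differs from compound 2 by trifluoromethoxy in place of iodo on an aromatic carbon. Among the measured compounds shown here, the one measured step, iodo in place of nitro, does not carry over to this change, so no comparison bears on it directly. For the measured compounds named here, with only one step and the shared core unchanged, compound 3 is expected to stay close to compound 2, estimated as a 1.4-fold lower number from compound 2 to compound 3 (0.15 log units; within the scatter). Compound 3 is thus estimated at 6000 nM, within 2500 nM to 20000 nM.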

Compound 3, solubility: 9900 nM
For compound 3 the middle estimate is 1.7-fold (0.22 log units) below the measured one; measured number inside the range.
By their numbers in this assay, from the lowest: compound 1; then compounds 2 and 3 (each within the scatter of the next).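

In this assay, trifluoromethoxy in place of iodo gives a 1.2-fold higher number from compound 2 to compound 3 (0.07 log units; within the scatter), so the two groups cannot be told apart at this position, despite their different heavy-atom counts. Trifluoromethoxy in place of nitro gives an 8.3-fold higher number from compound 1 to compound 3 (0.92 log units; beyond the scatter), so compound 1 now stands apart from two replacements rather than one. No measurement available here accounts for either result.

On these data alone, whether an amine, a carboxylic acid or a methoxy group at this position would sit with compound 2 and compound 3 or with compound 1 remains open. So does whether these swaps read the same when made elsewhere on the shared core.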